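Series notes: aryl-piperazine propylamino nicotinamides, step to compound 4

The compounds below may be only part of what the source reports. "The series", "measured", "known", "first", "only" and "open" are said of these compounds alone.

Measured so far in a functional assay for antagonist activity at Alpha-1A adrenergic receptor (Oryctolagus cuniculus); a higher number here means weaker binding, a lower number tighter binding:
- compound 1 `COc1ccccc1N1CCN(CCCNc2ncccc2C(=O)NC(C)(C)C)CC1` gives 1.26 nM
- compound 2 `CNC(=O)c1cccnc1NCCCN1CCN(c2ccccc2OC)CC1` gives 1 nM
- compound 3 `CN(C)C(=O)c1cccnc1NCCCN1CCN(c2ccccc2O)CC1` gives 5.01 nM

Compound 3 stands highest of the three numbers in this assay; its nearest neighbour is compound 1 and its furthest is compound 2, both gaps beyond the scatter. The single-change step on record, a 1.3-fold lower number from compound 1 to compound 2 (0.10 log units; within the scatter), concerns the amide nitrogen and stays within the scatter; it does not touch the aryl ring.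

Compound 4 `Cc1ccccc1N1CCN(CCCNc2ncccc2C(=O)N(C)C)CC1` differs from compound 3 by methyl in place of hydroxy on an aromatic carbon, the change sitting on an aromatic carbon of a six-membered aromatic ring of carbon only, ortho to a large group. Within the data shown here, no measured pair isolates this hydroxy-to-methyl exchange; compounds 1 and 2 carry methoxy on that ring but also a different amide, so their values give no clean step. Among the measured compounds shown here, with no bearing step, the expectation for compound 4 is a number near compound 3, with no step beyond the scatter claimed: a 1.4-fold lower number from compound 3 to compound 4 (0.16 log units; within the scatter) is the estimated step. Compound 4 is estimated at 3.5 nM in this assay, with a range from 1 nM to 12 nM.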

Compound 4, dissociation constant: 2 nM
Estimate against measurement, compound 4: 1.8-fold (0.24 log units) above, and the stated range covers the measured number.
By their numbers in this assay, from the lowest: compounds 2, 1 and 4 (each within the scatter of the next); then compound 3.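

In this assay, among these compounds, methyl in place of hydroxy on an aromatic carbon gives a 2.5-fold lower number from compound 3 to compound 4 (0.40 log units; beyond the scatter), a modest change and the first single-change step on record that lies beyond the scatter. Among the compounds shown here, it is also the first step to read this place on the six-membered aromatic ring of carbon only, where the earlier step concerned only the amide nitrogen. Going from 2-hydroxyphenyl to 2-methylphenyl removes the hydrogen-bond donor and acceptor counted for hydroxy, and the number falls rather than rises, so neither is required at this place for a low number in this series. Nothing on record accounts for the size or direction of this step.

As far as these compounds go, it remains open whether the step carries over to the amides of compound 1 and compound 2. An amine, a carboxylic acid or a longer chain such as ethyl at this place also remains untested among the compounds shown.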